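Swapping the Chlorophenyl Ring for a Thiophene

The source may report more compounds than this note shows. Statements on the series, on what has been measured and on what is new or still open speak of the compounds shown alone.

Compound 2 `COc1nc(-c2nc3ccccc3n2C)cc(-c2ccc(Cl)cc2)c1C#N` stands at the low end of the two numbers recorded in a functional assay on aorta (Rattus norvegicus, strain Wister) (on this read-out higher numbers stand for weaker inhibition and lower numbers for stronger inhibition), where compound 2 gives 145000 nM. Its only companion, compound 1 `COc1nc(-c2nc3ccccc3[nH]2)cc(-c2ccc(Cl)cc2)c1C#N`, carries a hydrogen instead of a methyl on the aromatic nitrogen; in this assay compound 1 gives 286000 nM. For the measured compounds named here, the single measured step, a 2.0-fold lower number from compound 1 to compound 2 (0.29 log units; within the scatter), stays inside the range that repeated measurements of this kind usually cover, so the two compounds cannot be ranked against each other.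

Compound 3 `COc1nc(-c2nc3ccccc3n2C)cc(-c2cccs2)c1C#N` has not been measured yet. It differs from compound 2 in one place: thiophen-2-yl in place of 4-chlorophenyl on an aromatic carbon. Going by the values given here, no measured step touches this place; the one step that exists concerns the methyl on the aromatic nitrogen and is of a different kind, so it gives no guidance on exchanging one aromatic ring for another here. With no comparison to lean on, the expectation for compound 3 in this assay is a number near that of compound 2, so that the expected step of no change at the digits printed from compound 2 to compound 3 (within the scatter) stays within the scatter. Compound 3 is therefore estimated at 145000 nM, with a range from 50000 nM to 400000 nM.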

Compound 3, half-maximal inhibitory concentration: 312000 nM
The estimate for compound 3 lay 2.2-fold (0.33 log units) below the measured number, and the stated range covers the measured number.
By their numbers in this assay, from the lowest: compounds 2, 1 and 3 (each within the scatter of the next, the first and the last beyond it).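

For the compounds shown here, this is the first measured change at this position, the aromatic carbon ortho to the cyano group, and in this assay the step is a 2.2-fold higher number from compound 2 to compound 3 (0.33 log units; beyond the scatter), a modest move but one that, unlike the change on the aromatic nitrogen, lies beyond the scatter. The position therefore registers the exchange of one aromatic ring for another, and of these two groups the 4-chlorophenyl of compound 2 gives the stronger inhibition, although the difference is small and both numbers remain high. The step changes several things at once, replacing a six-membered ring of carbon carrying chlorine with a five-membered ring containing sulfur, and no measurement here bears on why the number moved.

A plain phenyl ring without the chlorine would show how much of the step follows the chlorine, and thiophen-3-yl would show whether the point of attachment on the thiophene matters. Also open, going by these compounds, is how this position responds to groups of a different kind, such as a morpholine ring, a carboxylic acid or a longer alkyl chain, and whether the thiophene gives a similar step when the aromatic nitrogen carries hydrogen instead of methyl.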